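A few compounds are considered here, and "the series" means these few. Any claim that something is new, unique, unknown or untested is made for them only; others in the source may bear on it.

Compound 1 `COc1ccc(C(=O)Oc2cc3c(cc2C)[C@@H](C(C)C)CC=C3C)cc1` gives 80.1% in a functional assay on MCF7 cells (Homo sapiens) for antiproliferative activity, read by sulforhodamine B assay, with a stated time of 48 h, tested at 50 uM; on this read-out lower numbers stand for less inhibition and higher numbers for more inhibition at the one concentration tested (going by the name of the read-out).
Compound 2 `CC1=CC[C@H](C(C)C)c2cc(C)c(OC(=O)c3ccc([N+](=O)[O-])cc3)cc21` gives 72.9% in this assay.
Compound 3 `CC1=CC[C@H](C(C)C)c2cc(C)c(OC(=O)c3ccc(C(F)(F)F)cc3)cc21` gives 40.4% in this assay.

Compound 2 stands second highest of the three numbers: its gap to compound 1, a number 7.2 percentage points lower from compound 1 to compound 2 (within the scatter), is within the scatter, whereas a number 32.5 percentage points lower from compound 2 to compound 3 (beyond the scatter) is a large step. Compound 4 `CC1=CC[C@H](C(C)C)c2cc(C)c(OC(=O)Nc3ccccc3)cc21` is not yet measured; it differs from compound 2 by anilino in place of 4-nitrophenyl on a carbonyl carbon, on a carbonyl carbon. Within the data shown here, no measured step swaps the whole aryl group in this way. Among the measured compounds shown here, the measured steps show only that a change on that ring can move the number a lot, as in a number 39.7 percentage points lower from compound 1 to compound 3 (beyond the scatter) and a number 32.5 percentage points lower from compound 2 to compound 3 (beyond the scatter), or hardly at all, as in a number 7.2 percentage points lower from compound 1 to compound 2 (within the scatter). For compound 4 a moderate fall is expected, a number 17.9 percentage points lower from compound 2 to compound 4 (beyond the scatter), with a wide range. Compound 4 is estimated at 55%, between 25% and 80%.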

Compound 4, a percentage reported as inhibition, at one concentration (the size of the read-out at that concentration, not a potency): 75.1%
Compound 4: the middle estimate sits 20.1 percentage points below what was measured; low and high end bracket the measured number.
By their numbers in this assay, from the lowest: compound 3; then compounds 2, 4 and 1 (each within the scatter of the next).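

Swapping the whole 4-nitrophenyl group for anilino on this carbonyl carbon, a larger change than the earlier swaps on the ring, leaves the number in place: a number 2.2 percentage points higher from compound 2 to compound 4 (within the scatter), and a number 5 percentage points lower from compound 1 to compound 4 (within the scatter). So the aromatic ring can be attached through a different link, one that brings in a hydrogen-bond donor, with no change beyond the scatter. No evidence at hand explains this result. Still open, from the compounds shown here alone, is whether the aromatic ring is needed at all, which a butylamino chain in place of anilino would test.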